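The source may report more compounds than this note shows. Statements on the series, on what has been measured and on what is new or still open speak of the compounds shown alone.

Working notes on the series.

Compound 1 `COC(=O)C1=C(C)N=C(C)/C(=C(\O)OC)C1c1ccc(F)cc1` and compound 2 `COC(=O)C1=C(C)N=C(C)/C(=C(\O)OC)C1c1ccccc1I` share one core and differ only in the aryl group on the saturated ring carbon. In a functional assay (muscle tissue) with Cavia porcellus as the target (a higher number here means that more compound is needed for the effect, a lower number that less compound is needed), compound 1 gives 129 nM, while compound 2 gives 46.8 nM. Among the compounds with values here, the step of a 2.8-fold lower number from compound 1 to compound 2 (0.44 log units; beyond the scatter) is the only measured step so far. Within the data shown here, on these two numbers compound 2 stands lowest, with compound 1 as its only neighbour.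

Compound 3 `COC(=O)C1=C(C)N=C(C)/C(=C(\O)OC)C1c1cccc(I)c1` is the next member. Its change from compound 2 is 3-iodophenyl in place of 2-iodophenyl on a saturated ring carbon.

Among the measured compounds shown here, the single measured step bears on this only loosely: it changes both the halogen and its place on the phenyl ring, whereas the move from compound 2 to compound 3 keeps the halogen and shifts its place only. For the measured compounds named here, nothing among the measured compounds shows how a 3-iodophenyl group behaves here. The expectation is therefore a step near the scatter in either direction, as a 1.5-fold higher number from compound 2 to compound 3 (0.17 log units; within the scatter), with no strong case for a gain. Compound 3 is estimated at 70 nM in this assay, within a range from 25 nM to 200 nM.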

Compound 3, half-maximal effective concentration: 41.7 nM
For compound 3 the middle estimate is 1.7-fold (0.22 log units) above the measured one; low and high end bracket the measured number.
By their numbers in this assay, from the lowest: compounds 3 and 2 (each within the scatter of the next); then compound 1.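

The shift from 2-iodophenyl to 3-iodophenyl on the saturated ring carbon keeps the halogen and moves only its place on the phenyl ring, and in this assay it gives a 1.1-fold lower number from compound 2 to compound 3 (0.05 log units; within the scatter), so for these two compounds the place of the iodine makes no reading difference, something the earlier pair could not show with halogen and place changing together. Set against the 4-fluorophenyl group, the 3-iodophenyl group gives a 3.1-fold lower number from compound 1 to compound 3 (0.49 log units; beyond the scatter), which leaves both iodophenyl compounds apart from compound 1 beyond the scatter. No measurement at hand accounts for either step.

Whether the separation from compound 1 follows the halogen or its place on the phenyl ring stays open, as no compound shown carries iodine and fluorine at the same place; a 4-iodophenyl or a 3-fluorophenyl group on the saturated ring carbon would separate the two. Also open, as far as these compounds go, is how this position responds to an unsubstituted phenyl group, or to a phenyl group carrying something other than a halogen, such as an amine or a nitrile.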